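Replacing 4-fluorophenyl on a sulfonamide nitrogen

The compounds below may be only part of what the source reports. "The series", "measured", "known", "first", "only" and "open" are said of these compounds alone.

In a physicochemical assay for lipophilicity, at pH 7.4 (a lower number here means a more polar compound, a higher number a more lipophilic compound), compound 1 (`CC(C)CN(c1ccc(F)cc1)S(=O)(=O)c1ccc2c(c1)C(O)CC(C1CCOCC1)O2`) gives 3.39 and is the lower of the two measured compounds. Compound 2 (`CCc1ccc(N(CC(C)C)S(=O)(=O)c2ccc3nc(C4CCOCC4)cc(O)c3c2)cc1`) gives 4.97 and the gap between the two lies beyond the scatter. They differ in more than one place, however, so this gap offers no guide to a single exchange.

Compound 3 (`CC(C)CN(C1CCc2ccc(F)cc21)S(=O)(=O)c1ccc2c(c1)C(O)CC(C1CCOCC1)O2`) carries 6-fluoro-2,3-dihydro-1H-inden-1-yl in place of 4-fluorophenyl on a sulfonamide nitrogen and keeps the rest of compound 1. The entering group adds one five-membered non-aromatic ring of carbon only. For the measured compounds named here, no measured pair isolates this exchange, so the expectation rests on the structural change alone.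

A moderate rise in this assay is expected, estimated as a number 0.51 log units higher from compound 1 to compound 3 (beyond the scatter) for this step. For compound 3 the estimate is 3.9 with an expected range from 3.4 to 4.4 in this measurement.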

Compound 3, distribution coefficient: 3.94
For compound 3 the middle estimate is 0.04 log units below the measured one; the measured number falls inside the stated range.
By their numbers in this assay, from the lowest: compound 1; then compound 3; then compound 2.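

For the compounds shown here, on a sulfonamide nitrogen, 6-fluoro-2,3-dihydro-1H-inden-1-yl in place of 4-fluorophenyl gives the first single-place comparison; in this assay it reads as a number 0.55 log units higher from compound 1 to compound 3 (beyond the scatter). Both groups carry no hydrogen-bond donors, no hydrogen-bond acceptors and no net charge, so this step goes with an added five-membered non-aromatic ring of carbon only, with those counts unchanged. Nothing available explains the size of the step.

This single exchange cannot separate the contribution of the added ring from that of the changed attachment to the nitrogen. Still open, on these data alone, are how an amine or a carboxylic acid on this group would read in this assay, and whether the same exchange gives a similar step on the core of compound 2.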